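Swapping a Saturated Ring for an Aromatic One

This account rests on a few compounds, and the source may have more. Where it says the series, first, only, none or still open, it means among the compounds named here.

Measured compounds:
compound 1, `c1cc(OC2CCCCC2)ccc1NC1=NCCO1`: 20800 nM
compound 2, `c1cc(NC2=NCCO2)cc(OC2CCCCC2)c1`: 12000 nM
compound 3, `c1ccc(Oc2ccc(NC3=NCCO3)cc2)cc1`: 3100 nM

All three were tested in a functional assay on M21 cells (Homo sapiens) for inhibition, read by sulforhodamine B assay, with a stated time of 48 h; a higher number here means a weaker inhibitor of growth, a lower number a stronger inhibitor of growth. Compound 1 gives 20800 nM and compound 2 gives 12000 nM; these two numbers lie within the usual scatter of each other, so nothing separates them. Compound 3 gives 3100 nM, a lower number than either. Compound 1 and compound 2 contain the same atoms joined differently; the difference between their two cores is not broken down here. Compound 3 is compound 1 with phenyl in place of cyclohexyl on an oxygen on an aromatic ring, and that one change gave a 6.7-fold lower number from compound 1 to compound 3 (0.83 log units; beyond the scatter).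

The unmeasured compound 4, `c1ccc(Oc2cccc(NC3=NCCO3)c2)cc1`, is built from compound 2 by the very same change, (phenyl in place of cyclohexyl on an oxygen on an aromatic ring); the place where the change happens is described in the same words for both pairs, so this is the same change made on the other core. The expected step is therefore taken from the one seen. An improvement for compound 4 of about a 6.7-fold lower number from compound 2 to compound 4 (0.82 log units; beyond the scatter) is expected because a 6.7-fold lower number from compound 1 to compound 3 (0.83 log units; beyond the scatter) was the outcome of the same change on compound 1. On that basis compound 4 is estimated to give about 1800 nM in this assay, most likely somewhere between 600 nM and 5500 nM. Within the data shown here, with only one earlier instance of the change, and on a different core, the range is kept wide.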

Compound 4, concentration for 50% growth inhibition: 9600 nM
Compound 4: middle estimate off by 5.3-fold (0.73 log units), on the low side, and the stated range ends below it.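

In this assay, putting phenyl in place of cyclohexyl on the core of compound 2 gave a 1.3-fold lower number from compound 2 to compound 4 (0.10 log units; within the scatter), so on this core the swap produced no difference that can be told apart from the ordinary spread of repeated measurements. The swap therefore did not carry over from one core to the other with its size intact, as setting the two results side by side shows: the same change on two cores in this assay, a 6.7-fold lower number (0.83 log units; beyond the scatter) from compound 1 to compound 3 and a 1.3-fold lower number (0.10 log units; within the scatter) from compound 2 to compound 4, 5.4-fold (0.73 log units) apart, beyond the scatter of two such steps. Among these compounds, the gain seen on the core of compound 1 thus cannot be assumed on a closely related core, but with only one pair on each core, these results do not show why the two outcomes differ or how the change would behave on any further core.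

The compounds shown leave open whether the two cores would also part ways with other groups on that oxygen, such as a longer chain or a ring bearing an amine or a carboxylic acid. They also leave open whether the same contrast between the cores would appear in any test other than this assay.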